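The source may report more compounds than this note shows. Statements on the series, on what has been measured and on what is new or still open speak of the compounds shown alone.

Of the compounds shown here, three of a shared ribosylated core have been measured so far in a functional assay on HL-60 cells (Homo sapiens) for antiproliferative activity, read by XTT assay, with a stated time of 72 h; a higher number here means a weaker inhibitor, a lower number a stronger inhibitor. Compound 3 `C#Cc1cn([C@@H]2O[C@H](CO)[C@@H](O)[C@H]2O)c2ncnc(C)c12` stands lowest of the two numbers, at 1110 nM. Within the data shown here, compound 2 `Cc1ncnc2c1c(I)cn2[C@@H]1O[C@H](CO)[C@@H](O)[C@H]1O` gives 2650 nM, and the step of a 2.4-fold lower number from compound 2 to compound 3 (0.38 log units; beyond the scatter) is the only completed single-point change. Compound 1 `Nc1nc(N)c2c(-c3ccsc3)cn([C@@H]3O[C@H](CO)[C@@H](O)[C@H]3O)c2n1` gives > 20000 nM, which is a limit of this assay rather than a number (the limit of > 20000 nM in this assay, at which 1 of the 3 values shown sits).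

Compound 4 `C#Cc1cn([C@@H]2O[C@H](CO)[C@@H](O)[C@H]2O)c2ncnc(N(C)C)c12` is not yet measured. It differs from compound 3 in one place: dimethylamino in place of methyl on an aromatic carbon. No measured step touches this position, since the one step shown exchanges iodo for ethynyl elsewhere on the core, so it offers no direct guide to the size or direction of the change. Compound 1 carries a different pattern at several positions at once and sits at the limit, so its value and that of compound 3 cannot be read as a single step either.

Among the measured compounds shown here, with no step bearing on it, the expectation for compound 4 is open, and the estimated step of a 1.6-fold lower number from compound 3 to compound 4 (0.20 log units; within the scatter) is set near no change, with a wide range on both sides. Compound 4 is therefore estimated at 700 nM, between 120 nM and 4500 nM.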

Compound 4, half-maximal inhibitory concentration: 290 nM
Beside the measured number, compound 4's estimate is 2.4-fold (0.38 log units) above it, within the range that was stated.
By their numbers in this assay, from the lowest: compound 4; then compound 3; then compound 2. At a limit, above all of these: compound 1.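

In this assay, among these compounds, the change at this aromatic carbon of the six-membered aromatic ring with 2 nitrogen gives a 3.8-fold lower number from compound 3 to compound 4 (0.58 log units; beyond the scatter), the only measured step at this place, and it shows that the number here responds to the group carried there. With the ethynyl group held constant, methyl is not needed at this position, since dimethylamino, which enters with a nitrogen and a hydrogen-bond acceptor, goes with a lower number, and this step lies beyond the scatter as does the step elsewhere on the core, a 2.4-fold lower number from compound 2 to compound 3 (0.38 log units; beyond the scatter). Nothing measured among these compounds gives a reason for the change at this position.

Going by these compounds, whether the gain depends on the two methyl groups on the nitrogen or on the nitrogen alone stays open, and a primary amine, methylamino, a pyrrolidine ring or a methoxy group at the same carbon would separate these readings. Compound 1 gives > 20000 nM, which is a limit of the assay and not a number, and with its several differences it says nothing about this position.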